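Sulfonamide nitrogen substitution in a PLK2 dihydropteridinone series

A few compounds are considered here, and "the series" means these few. Any claim that something is new, unique, unknown or untested is made for them only; others in the source may bear on it.

Measured compounds:
compound 1 `CCC1C(=O)N(C)c2cnc(Nc3ccc(S(=O)(=O)NCC(C)C)cc3)nc2N1c1ccn(C)n1` gives 311 nM in an assay for inhibition of serine/threonine-protein kinase PLK2 (Homo sapiens), read by FRET and Z'-LYTE, with a stated time of 1 h; on this read-out lower numbers stand for stronger inhibition and higher numbers for weaker inhibition
compound 2 `CCCCNS(=O)(=O)c1ccc(Nc2ncc3c(n2)N(C2CCCC2)[C@H](CC)C(=O)N3C)cc1` gives 19.9 nM in this assay

Compound 2 holds the lowest of the two numbers in this assay; the nearest, compound 1, stands at a gap beyond the scatter. Compound 3 `CC[C@@H]1C(=O)N(C)c2cnc(Nc3ccc(S(N)(=O)=O)cc3)nc2N1C1CCCC1` is not yet measured. It differs from compound 2 by hydrogen in place of butyl on a sulfonamide nitrogen. For the measured compounds named here, no measured pair shows this change, so the direction rests on expectation alone. A modest rise in the number is expected, a 2.0-fold higher number from compound 2 to compound 3 (0.30 log units; within the scatter), though within reach of the scatter. For compound 3 the estimate is 40 nM, with a range from 10 nM to 160 nM.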

Compound 3, half-maximal inhibitory concentration: 10.2 nM
Estimate against measurement, compound 3: 3.9-fold (0.59 log units) above; measured number inside the range.
By their numbers in this assay, from the lowest: compounds 3 and 2 (each within the scatter of the next); then compound 1.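

In this assay hydrogen in place of butyl on a sulfonamide nitrogen gives a 2.0-fold lower number from compound 2 to compound 3 (0.29 log units; within the scatter), so this pair shows no loss on taking the chain away. The butyl is therefore not required at this position for a number at this level, and the plain sulfamoyl of compound 3 stands level with the butylsulfamoyl of compound 2. Nothing measured here gives a reason for this result.

Open, from the compounds shown here alone, is whether methyl, a longer chain, or a chain carrying an amine or a carboxylic acid on this nitrogen would also leave the number unchanged. Equally open, going by these compounds, is whether the same change would read alike with the other substituents of compound 1.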